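The source may hold more compounds than are shown below. What is called first, only, known or untested is meant among the compounds shown, and "the series" means these compounds.

Of the compounds shown here, three have been measured in an assay on HEK293 cells for activation of Kir3.1/Kir3.2 (Homo sapiens), read by thallium flux; on this read-out higher numbers stand for an effect only at larger amounts of compound and lower numbers for an effect already at smaller amounts. Compound 1 `Cc1cc(NC(=O)Cn2nnc(-c3ccccc3)n2)n(C(C)C)n1` gives 556 nM, and compound 2 `CC1CC1c1cc(NC(=O)Cn2nnc(-c3ccccc3)n2)n(C2CCCCC2)n1` gives 843 nM. Compound 3 `Cc1cc(NC(=O)Cn2nnc(-c3ccccn3)n2)n(C2CCCCC2)n1` carries a pyridin-2-yl group where compounds 1 and 2 carry a plain phenyl. In this assay compound 3 gives 14600 nM, the highest number of the three; its gap to compound 2 and its gap to compound 1 both lie well beyond the usual scatter, so compound 3 needs clearly larger amounts than either.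

Compound 4 `Cc1cc(NC(=O)Cn2nnc(-c3cccc(F)c3)n2)n(C2CCCCC2)n1` has not yet been measured in this assay. It differs from compound 3 in one place: 3-fluorophenyl in place of pyridin-2-yl on an aromatic carbon. With this change the ring on the tetrazole goes back to a carbon-only ring, as in compounds 1 and 2, which both give far lower numbers than compound 3.

Going by the values given here, no directly comparable step exists in the measured set, so the expectation rests on that pattern alone. Compound 4 is expected to move back toward compounds 1 and 2, a step of a 12-fold lower number from compound 3 to compound 4 (1.09 log units; beyond the scatter) that is estimated to be a large drop. The estimate for compound 4 is 1200 nM, with a range from 350 nM to 4500 nM.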

Compound 4, half-maximal effective concentration: 81 nM
For compound 4 the middle estimate is 15-fold (1.17 log units) above the measured one, outside the stated range (below it).
By their numbers in this assay, from the lowest: compound 4; then compounds 1 and 2 (each within the scatter of the next); then compound 3.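

In this assay, going by these compounds alone, exchanging pyridin-2-yl for 3-fluorophenyl on the aromatic carbon of the five-membered ring with 4 nitrogen gives a 180-fold lower number from compound 3 to compound 4 (2.26 log units; beyond the scatter), the first comparison here in which only this group changes. It shows that the group at this position can by itself strongly shift the amount of compound needed. Two things change together in this step, since a ring nitrogen leaves and a fluorine enters, and nothing available explains the size of the step.

As far as these compounds go, how much of the step belongs to the lost ring nitrogen and how much to the added fluorine stays open. Also open, from the compounds shown here alone, is how this position would respond to pyridin-3-yl, 3-chlorophenyl or 3-methoxyphenyl on the same core.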